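Sulfonamide replacement in an arylsulfonyl tetralin series

The compounds below may be only part of what the source reports. "The series", "measured", "known", "first", "only" and "open" are said of these compounds alone.

Measured so far:
compound 1 `NC(=O)CNC[C@@H]1CCCc2cc(S(=O)(=O)c3cccc(F)c3)ccc21`: 0.1 nM
compound 2 `CNCC(=O)NC[C@@H]1CCCc2cc(S(=O)(=O)c3cccc(F)c3)ccc21`: 0.159 nM
compound 3 `CC(C)(O)C(=O)NC[C@@H]1CCCc2cc(S(=O)(=O)c3cccc(F)c3)ccc21`: 2 nM

In an assay on isolated protein for displacement of a labelled ligand from 5-hydroxytryptamine receptor 6 (Homo sapiens) (a higher number here means a weaker inhibitor, a lower number a stronger inhibitor), compound 3 gives the highest number of the three measured compounds; both steps onto it are large, a 20-fold higher number from compound 1 to compound 3 (1.30 log units; beyond the scatter) and a 13-fold higher number from compound 2 to compound 3 (1.10 log units; beyond the scatter), whereas a 1.6-fold higher number from compound 1 to compound 2 (0.20 log units; within the scatter) stays within the scatter. Compound 4 `CS(=O)(=O)NC[C@@H]1CCCc2cc(S(=O)(=O)c3cccc(F)c3)ccc21` differs from compound 3 by methylsulfonyl in place of (1-hydroxy-1-methylethyl)carbonyl on an amine nitrogen. Neither measured step covers a sulfonyl group on this amine nitrogen, so the bearing is indirect: the two large steps show that the substituent on this nitrogen moves the number strongly, and compound 4, like compound 3, carries neither the carbamoylmethyl of compound 1 nor the ((methylamino)methyl)carbonyl of compound 2. The expectation is therefore a number close to that of compound 3, with no step beyond the scatter in this assay, a 1.5-fold higher number from compound 3 to compound 4 (0.18 log units; within the scatter). For compound 4 the estimated value in this assay is 3 nM, expected to lie between 0.8 nM and 12 nM.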

Compound 4, inhibition constant: 0.2 nM
The estimate for compound 4 lay 15-fold (1.18 log units) above the measured number; the measured number lies below the stated range.
By their numbers in this assay, from the lowest: compounds 1, 2 and 4 (each within the scatter of the next); then compound 3.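

In this assay, the step of a 10-fold lower number from compound 3 to compound 4 (1.00 log units; beyond the scatter) shows that the number at this amine nitrogen can fall again without the carbamoylmethyl of compound 1 or the ((methylamino)methyl)carbonyl of compound 2, since methylsulfonyl gives a 1.3-fold higher number from compound 2 to compound 4 (0.10 log units; within the scatter) and a 2.0-fold higher number from compound 1 to compound 4 (0.30 log units; within the scatter). The substituents of compound 1 and compound 2 each hold a further nitrogen and methylsulfonyl holds none, so among these compounds a low number does not depend on one, and the high number stands with the (1-hydroxy-1-methylethyl)carbonyl of compound 3 alone. Nothing at hand accounts for the gap between compound 3 and compound 4.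

Open, as far as these compounds go, is whether a longer chain on the sulfonyl, such as ethylsulfonyl, keeps the number of compound 4. Also open, from the compounds shown here alone, is whether a plain acetyl on this nitrogen sits with compound 4 or with compound 3.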